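This account rests on a few compounds, and the source may have more. Where it says the series, first, only, none or still open, it means among the compounds named here.

Measured so far in an assay on isolated protein (strain albino) for antagonist activity at Voltage-dependent L-type calcium channel subunit alpha-1C (Cavia porcellus); a higher number here means a weaker inhibitor, a lower number a stronger inhibitor:
compound 1, `COC(=O)C1=C(C)NC(C)=C(C(=O)OC(C)C)C1c1cnc(SC)n1Nc1ccccc1`, gives 6.35 nM;
compound 2, `CCOC(=O)C1=C(C)NC(C)=C(C(=O)OCc2ccccc2)C1c1cnc(SC)n1Nc1ccccc1`, gives 1.86 nM;
compound 3, `COCCOC(=O)C1=C(C)NC(C)=C(C(=O)OC(C)C)C1c1cnc(SC)n1Nc1ccccc1`, gives 53.4 nM.

Compound 3 has the highest number of the three in this assay; compound 1 is nearest, compound 2 furthest. The unmeasured compound 4, `CSc1ncc(C2C(C(=O)OCc3ccccc3)=C(C)NC(C)=C2C(=O)OC(C)C)n1Nc1ccccc1`, differs from compound 3 by phenyl in place of methoxymethyl on a saturated chain carbon bound to an oxygen next to a carbonyl group. For the measured compounds named here, one measured step bears on this: an 8.4-fold higher number from compound 1 to compound 3 (0.92 log units; beyond the scatter), a modest weakening when methoxymethyl entered at this position. Compound 2, which also carries a benzyl ester, gives a low number in this assay, so the benzyl group is not expected to be unfavourable there. Replacing methoxymethyl by phenyl is therefore expected to undo most of that weakening, and compound 4 is estimated at 4 nM (range 1.5 nM to 12 nM), a step of a 13-fold lower number from compound 3 to compound 4 (1.13 log units; beyond the scatter) toward a stronger inhibitor.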

Compound 4, half-maximal inhibitory concentration: 7.24 nM
For compound 4 the middle estimate is 1.8-fold (0.26 log units) below the measured one; measured number inside the range.
By their numbers in this assay, from the lowest: compound 2; then compounds 1 and 4 (each within the scatter of the next); then compound 3.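

Swapping methoxymethyl for phenyl gives a 7.4-fold lower number from compound 3 to compound 4 (0.87 log units; beyond the scatter) and so recovers the lost strength, while adding phenyl in place of hydrogen gives a 1.1-fold higher number from compound 1 to compound 4 (0.06 log units; within the scatter) and so leaves the number level with the methyl ester. At the same kind of place in the other ester, methyl in place of hydrogen does matter, with a 3.9-fold higher number from compound 2 to compound 4 (0.59 log units; beyond the scatter) as the step. Nothing here explains these differences.

As far as these compounds go, it remains open whether the 2-methoxyethyl penalty comes from its oxygen or from the chain as a whole. A plain butyl chain, or a chain ending in an amine, could help to separate these.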